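The source may report more compounds than this note shows. Statements on the series, on what has been measured and on what is new or still open speak of the compounds shown alone.

Within the data shown here, in a physicochemical assay for solubility, read by spectrophotometry, in phosphate buffer, with a stated time of 18 h, at pH 7.4 (a higher number here means a more soluble compound, a lower number a less soluble compound), three compounds on a shared core have numbers so far. Compound 1 `Cc1ccc(-c2nc3c(c(C)nn3-c3ccccc3)c(-c3ccccc3O)c2C#N)cc1` gives 26000 nM, compound 2 `Cc1ccccc1-c1nc2c(c(C)nn2-c2ccccc2)c(-c2ccccc2O)c1C#N` gives 21000 nM, and compound 3 `Cc1nn(-c2ccccc2)c2nc(-c3ccc(C(F)(F)F)cc3)c(C#N)c(-c3ccccc3O)c12` gives 3500 nM. Compound 3 thus stands lowest of the three, and its gaps to both others lie beyond the scatter.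

Compound 4 `Cc1nn(-c2ccccc2)c2nc(-c3ccc(I)cc3)c(C#N)c(-c3ccccc3O)c12` departs from compound 3 in one place: iodo in place of trifluoromethyl on an aromatic carbon.

Among the measured compounds shown here, no measured step carries iodo, so none gives the size of this change directly. The nearest evidence is a 7.4-fold lower number from compound 1 to compound 3 (0.87 log units; beyond the scatter), a modest step at this same place, with trifluoromethyl in place of methyl. a 6.0-fold lower number from compound 2 to compound 3 (0.78 log units; beyond the scatter) is also modest, while a 1.2-fold lower number from compound 1 to compound 2 (0.09 log units; within the scatter) stays within the scatter. These steps show that the number can shift when this aryl group changes, but they do not show how iodo compares with trifluoromethyl.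

On that basis, no step beyond the scatter is expected, with a slight lean towards the lower side. The expected step is a 1.4-fold lower number from compound 3 to compound 4 (0.15 log units; within the scatter). For compound 4, the estimated value is 2500 nM, with an expected range of 800 nM to 7000 nM.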

Compound 4, solubility: 1500 nM
Beside the measured number, compound 4's estimate is 1.7-fold (0.22 log units) above it, and the stated range covers the measured number.
By their numbers in this assay, from the lowest: compound 4; then compound 3; then compounds 2 and 1 (each within the scatter of the next).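

In this assay, iodo in place of trifluoromethyl gives a 2.3-fold lower number from compound 3 to compound 4 (0.37 log units; beyond the scatter) and so shows that this place on the aromatic ring still has room to go lower, even after the drop already seen with trifluoromethyl. Set against the earlier compounds that carry a methyl group on this aryl ring, the new compound reaches steps of a size that neither trifluoromethyl step reached, with iodo in place of methyl giving a 17-fold lower number from compound 1 to compound 4 (1.24 log units; beyond the scatter) and 4-iodophenyl in place of 2-methylphenyl giving a 14-fold lower number from compound 2 to compound 4 (1.15 log units; beyond the scatter) as the widest changes in the set. Nothing measured here explains why methyl, trifluoromethyl and iodo fall in this order at this place.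

The compounds shown carry only these small groups on the aryl ring, so it remains open whether an amine, a carboxylic acid or a methoxy group at this place would raise the number or lower it further. On these data alone, it also remains open whether chloro or bromo would behave as iodo does, and whether the step from trifluoromethyl to iodo would keep its size with other groups elsewhere on the shared core.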